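Aryl sulfone series: methoxy to fluoro on the sulfonyl aryl

The source may hold more compounds than are shown below. What is called first, only, known or untested is meant among the compounds shown, and "the series" means these compounds.

Measured compounds and their values in an ADME assay on microsomes from liver (Homo sapiens) for metabolic stability, tested at 2.5 uM; a lower number here means slower removal, a higher number faster removal of the compound:
compound 1, `COc1ccc(S(=O)(=O)c2cnc3cc(F)ccc3c2-c2ccc(F)cc2)cc1Cl`, gives 1.29 mL/min
compound 2, `COc1ccc(-c2c(S(=O)(=O)c3ccc(OC)cc3)cnc3cc(F)ccc23)cc1`, gives 1.18 mL/min
compound 3, `O=S(=O)(c1ccc(F)c(Cl)c1)c1cnc2cc(F)ccc2c1-c1ccc(F)cc1`, gives 0.69 mL/min

Compound 4, `COc1ccc(-c2c(S(=O)(=O)c3ccc(F)cc3)cnc3cc(F)ccc23)cc1`, has not yet been measured in this assay.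

Compound 3 is made from compound 1 by fluoro in place of methoxy on an aromatic carbon, and this gave a 1.9-fold lower number from compound 1 to compound 3 (0.27 log units; within the scatter). Compound 4 is made from compound 2 by fluoro in place of methoxy on an aromatic carbon. Going by the values given here, the two changes are the same kind of change, not the same: in compound 1 the place is also ortho to a chloro group (1 heavy atom), which has no counterpart in compound 2. The difference between the core of compound 1 and the core of compound 2 is not broken down here; their values in this assay lie within the usual scatter of each other.

For compound 4 the step from compound 2 is expected to be a 1.7-fold lower number from compound 2 to compound 4 (0.23 log units; within the scatter), resting on the step seen from compound 1 to compound 3, a 1.9-fold lower number from compound 1 to compound 3 (0.27 log units; within the scatter), and on the value of compound 2, 1.18 mL/min. Among the compounds with values here, with only one prior example of this change, the expectation is wide. Compound 4 is estimated at 0.7 mL/min, between 0.35 mL/min and 1.4 mL/min.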

Compound 4, intrinsic clearance in a liver preparation (reported as CLH), per the amount of preparation that the assay uses: 1.77 mL/min
The estimate for compound 4 lay 2.5-fold (0.40 log units) below the measured number, and the stated range ends below it.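

In this assay fluoro in place of methoxy gives a 1.5-fold higher number from compound 2 to compound 4 (0.18 log units; within the scatter), and the direction differs from the earlier case, so this change does not carry from one core to another in this series as a fixed step: the same change on two cores in this assay, a 1.9-fold lower number (0.27 log units; within the scatter) from compound 1 to compound 3 and a 1.5-fold higher number (0.18 log units; within the scatter) from compound 2 to compound 4, 2.8-fold (0.45 log units) apart, beyond the scatter of two such steps.
Each step taken alone lies within the scatter, so neither gives a reliable size or direction for the change; what stands beyond the scatter is only the gap between the two steps.
The two cores differ in more than one place, among them the chloro group that compound 1 carries and compound 2 lacks, and these pairs do not show which difference goes with the gap.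

Still open, on these data alone, is whether a third core would follow the step seen with compound 1 and compound 3, the step seen with compound 2 and compound 4, or neither. Also open, as far as these compounds go, is how an amine or a carboxylic acid in place of methoxy at this position would read in this assay.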